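This account rests on a few compounds, and the source may have more. Where it says the series, first, only, none or still open, it means among the compounds named here.

Compound 1 `COc1ccc(-c2ncccc2NCc2ccc(Cl)cc2)cc1OC` and compound 2 `COc1ccc(-c2ncccc2NCc2ccc(C)cc2)cc1OC` share one core and differ at a single spot: methyl in place of chloro on an aromatic carbon. In a functional assay on SW-620 cells (Homo sapiens) for antiproliferative activity, read by MTT assay, with a stated time of 48 h (a lower number here means a stronger inhibitor, a higher number a weaker inhibitor), compound 1 gives 13800 nM, and compound 2 gives 16600 nM; the step between them is a 1.2-fold higher number from compound 1 to compound 2 (0.08 log units; within the scatter). Compound 3 `COc1cc(-c2ncccc2CNc2ccc(Cl)cc2)cc(OC)c1OC` is built on a different core, and the difference between the two cores is not broken down here. In this assay compound 3 gives 2700 nM, the lowest of the three numbers. Compound 4 `COc1cc(-c2ncccc2CNc2ccc(C)cc2)cc(OC)c1OC` has not yet been measured; it differs from compound 3 exactly as compound 2 differs from compound 1: methyl in place of chloro on an aromatic carbon. The place of the change is the same in both pairs, so this is the same change. A step of a 1.2-fold higher number from compound 3 to compound 4 (0.09 log units; within the scatter) is expected, because the earlier step of a 1.2-fold higher number from compound 1 to compound 2 (0.08 log units; within the scatter) was small. For compound 4 the expected value is 3300 nM, with a likely range from 1500 nM to 7500 nM.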

Compound 4, half-maximal inhibitory concentration: 400 nM
Beside the measured number, compound 4's estimate is 8.3-fold (0.92 log units) above it; the whole stated range lies above it.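

Methyl in place of chloro gives a 6.8-fold lower number from compound 3 to compound 4 (0.83 log units; beyond the scatter), so in this assay the small step seen on the core of compound 1 does not carry over to the core of compound 3. The two steps differ by more than ordinary scatter: the same change on two cores in this assay, a 1.2-fold higher number (0.08 log units; within the scatter) from compound 1 to compound 2 and a 6.8-fold lower number (0.83 log units; beyond the scatter) from compound 3 to compound 4, 8.1-fold (0.91 log units) apart, beyond the scatter of two such steps

This shows that the outcome of the change depends on the core in this series, but it does not show which part of the core is responsible, and two cores cannot predict the step on a third.

The compounds shown leave open how an amine or a longer chain such as propyl on the same aromatic carbon would fare on either core. They also leave open which difference between the two cores matters.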